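The source may report more compounds than this note shows. Statements on the series, on what has been measured and on what is new or still open speak of the compounds shown alone.

Measured so far in an ADME assay on HepG2 2.2.15 cells (Homo sapiens) for cytotoxicity; a lower number here means that less compound is tolerated, a higher number that more compound is tolerated:
- Compound 1 `O=C(OCCc1c(-c2ccccc2Cl)c2cc(Cl)ccc2[nH]c1=O)c1ccco1`: 98000 nM
- Compound 2 `COc1cccc(/C=C/C(=O)OCCc2c(-c3ccccc3Cl)c3cc(Cl)ccc3[nH]c2=O)c1`: > 1300000 nM (a limit)
- Compound 3 `COc1ccc(/C=C/C(=O)OCCc2c(-c3ccccc3Cl)c3cc(Cl)ccc3[nH]c2=O)cc1`: > 1200000 nM (a limit)

Compound 3 has no exact number on this scale. For compound 3, > 1200000 nM is a limit of the assay. Compound 2 also has only a limit, and the comparison gives a step that the two limits leave unreadable from compound 2 to compound 3.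

Compound 4 `O=C(/C=C/c1cccc(C(F)(F)F)c1)OCCc1c(-c2ccccc2Cl)c2cc(Cl)ccc2[nH]c1=O` keeps the shared core and changes one group: 3-(trifluoromethyl)phenyl in place of 4-methoxyphenyl on a double-bonded chain carbon bound to a double-bonded chain carbon. In words, 3-(trifluoromethyl)phenyl takes the place of 4-methoxyphenyl on a double-bonded chain carbon bound to a double-bonded chain carbon.

Among the measured compounds shown here, no measured step makes this exact exchange. The nearest evidence is an at least 13-fold higher number from compound 1 to compound 2 (1.12 log units; beyond the scatter), together with an at least 12-fold higher number from compound 1 to compound 3 (1.08 log units; beyond the scatter). Both steps are large, and both replace furan-2-yl on a carbonyl carbon with a methoxyphenyl-bearing ethenyl group. Compound 4 keeps the ethenyl group, so it is expected to resemble compound 3 more than compound 1, given an at least 12-fold higher number from compound 1 to compound 3 (1.08 log units; beyond the scatter). No step beyond the scatter is therefore expected, although a limit on one side leaves this uncertain, and compound 4 may also return only a limit.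

The estimated change is an at least 1.3-fold lower number from compound 3 to compound 4 (0.12 log units; that floor lies within the scatter). For compound 4, the expected half-maximal cytotoxic concentration is 900000 nM, with an estimated range of 200000 nM to 1500000 nM.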

Compound 4, half-maximal cytotoxic concentration: > 1400000 nM
Compound 4 was reported as a limit (the forecaster's own chance of this, stated with the estimate: 55%); middle value at least 1.5-fold (0.19 log units) away from the limit.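

In this assay, compound 4 is also reported only as a limit of the assay, not as a number: the limit of > 1400000 nM in this assay, at which 1 of the 4 values shown sits.

Replacing furan-2-yl on a carbonyl carbon with 2-(3-(trifluoromethyl)phenyl)ethenyl gives an at least 14-fold higher number from compound 1 to compound 4 (1.15 log units; beyond the scatter), so the large rise seen earlier with the two methoxy-bearing groups also appears with a group that has no methoxy at all. Across these compounds, a 2-arylethenyl group with either methoxy or trifluoromethyl on the ring goes with a limit, and the only exact number belongs to the furan-2-yl compound, although the steps joining compound 2, compound 3 and compound 4 link limits and cannot be read, so nothing places these three in order.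

The compounds shown leave open how much of each of these three is really tolerated, and whether the rise comes from the ethenyl chain, the phenyl ring or both. An amine or a carboxylic acid in place of trifluoromethyl on the ring, or a furan-2-yl group carried on the ethenyl chain, would help separate these possibilities.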